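A methoxy group gives way to hydroxy

The compounds below may be only part of what the source reports. "The series", "measured", "known", "first", "only" and "open" are said of these compounds alone.

Values in an ADME assay on CNE-2 cells (Homo sapiens) for cytotoxicity, read by MTT assay, with a stated time of 48 h; a higher number here means a weaker inhibitor, a lower number a stronger inhibitor:
Compound 1 `COc1ccc(-c2cn(Cc3cc(C(F)(F)F)cc(C(F)(F)F)c3)nn2)cc1`: 14100 nM
Compound 2 `CC(C)(C)c1ccc(Cn2cc(-c3ccc(O)cc3)nn2)c(O)c1`: > 20000 nM (a limit)
Compound 3 `COc1ccc(-c2cn(Cc3ccc(C(C)(C)C)cc3)nn2)c(N)c1`: > 20000 nM (a limit)

Compound 3 stands at > 20000 nM, which is a limit of the assay and not a number. The series is largely defined by the limit of > 20000 nM in this assay, at which 2 of the 3 values shown sit. Compound 4 `CC(C)(C)c1ccc(Cn2cc(-c3ccc(O)cc3N)nn2)cc1` differs from compound 3 in one place: hydrogen in place of methyl on an oxygen on an aromatic ring, or methoxy to hydroxy. Within the data shown here, no measured pair isolates this change. No step beyond the scatter is expected in this assay, in either direction. The expected change is a step that the limit leaves unreadable from compound 3 to compound 4. Compound 4 is estimated at 24000 nM, with an expected range of 12000 nM to 48000 nM.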

Compound 4, half-maximal inhibitory concentration: 1600 nM
Compound 4: the middle estimate sits 15-fold (1.18 log units) above what was measured, outside the stated range (below it).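

Hydrogen in place of methyl on an oxygen on an aromatic ring gives, in this assay, an at least 12-fold lower number from compound 3 to compound 4 (1.09 log units; beyond the scatter), the first readable step in this series and the first sign that this oxygen matters here. Compound 3 stands at > 20000 nM, which is a limit of the assay and not a number. The step therefore has a lower bound only, and that limit marks much of the series: the limit of > 20000 nM in this assay, at which 2 of the 4 values shown sit.

This single pair shows no general pattern. Going by these compounds, whether an ethoxy group or a carboxylic acid in this place would keep the lower number remains open.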